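Chloro in place of trifluoromethyl: compound 1 to compound 4

The source may hold more compounds than are shown below. What is called first, only, known or untested is meant among the compounds shown, and "the series" means these compounds.

Among the compounds with values here, compound 1 `CCC/N=C1\S/C(=C\c2ccc(O)c(C(F)(F)F)c2)C(=O)N1c1ccccc1C` gives 3.8 in a physicochemical assay for lipophilicity, read by HPLC, at pH 7.4 (a lower number here means a more polar compound, a higher number a more lipophilic compound), the highest of the three numbers measured so far. Compound 2 `Cc1ccccc1N1C(=O)/C(=C/c2ccc(O)c(Cl)c2)S/C1=N\CCCF` gives 3.4 and compound 3 `COCC/N=C1\S/C(=C\c2ccc(O)c(Cl)c2)C(=O)N1c1ccccc1C` gives 2.9; both sit below compound 1 beyond the scatter, compound 3 furthest. Within the data shown here, the only single-point step measured, a number 0.50 log units lower from compound 2 to compound 3 (beyond the scatter), concerns the chain on the double-bonded nitrogen and does not touch the aromatic ring.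

Compound 4 `CCC/N=C1\S/C(=C\c2ccc(O)c(Cl)c2)C(=O)N1c1ccccc1C` differs from compound 1 by chloro in place of trifluoromethyl on an aromatic carbon, placed on an aromatic carbon of a six-membered aromatic ring of carbon only, ortho to a hydroxy group. Among the measured compounds shown here, no measured pair isolates this change. Compound 2 carries the same chloro as compound 4 but a fluoromethyl on the chain; compound 2 gives 3.4, whereas compound 1 gives 3.8. For the measured compounds named here, this pair differs in two places, so it shows only that the chloro-bearing analogue sits lower.

A small downward step, a number 0.30 log units lower from compound 1 to compound 4 (within the scatter), is therefore expected, roughly matching the gap between compound 1 and compound 2. Compound 4 is expected to give 3.5 in this assay, within 3.1 to 3.9.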

Compound 4, distribution coefficient: 3.8
Estimate against measurement, compound 4: 0.30 log units below; low and high end bracket the measured number.
By their numbers in this assay, from the lowest: compound 3; then compound 2; then compounds 1 and 4 (each within the scatter of the next).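

In this assay, chloro in place of trifluoromethyl on an aromatic carbon, ortho to a hydroxy group, now has a reading free of any change elsewhere, and with the chain of compound 1 held it gives no change at the digits printed from compound 1 to compound 4 (within the scatter) and no separation between the two groups at this position. With the chloro held, the chain now gives two further single-place readings beyond the scatter, a number 0.90 log units higher from compound 3 to compound 4 (beyond the scatter) and a number 0.40 log units higher from compound 2 to compound 4 (beyond the scatter), so among the single-place steps shown, both of these and the earlier methoxy step lie beyond the scatter, whereas the aromatic exchange does not. Nothing in hand gives a measured reason for either the match on the ring or the steps on the chain.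

The compounds shown leave open whether chloro and trifluoromethyl also read alike when the chain carries a fluoro or a methoxy, as in compound 2 and compound 3. They also leave open how a nitrile or a methoxy at the same aromatic carbon, or an amine or a longer chain on the double-bonded nitrogen, would read in this assay against compound 4.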